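The source may report more compounds than this note shows. Statements on the series, on what has been measured and on what is new or still open speak of the compounds shown alone.

Within the data shown here, in an assay on isolated protein for inhibition of ribosomal protein S6 kinase alpha-1 (Homo sapiens), read by mobility shift assay, tested at 30 uM (on this read-out higher numbers stand for more inhibition at the one concentration tested (going by the name of the read-out) and lower numbers for less inhibition), compound 2 `CC(C)(C)c1cc2nn(-c3ccccc3)c(N)c2c(=O)[nH]1` gives 5%, the higher of the two numbers measured so far; its nearest neighbour is compound 1 `Cc1cc2nn(-c3ccccc3)c(N)c2c(=O)[nH]1`, which in this assay gives -11%. Among the measured compounds shown here, the only step available, a number 16 percentage points higher from compound 1 to compound 2 (beyond the scatter), came from exchanging one carbon group for another at the same aromatic carbon of the shared core. Compound 3 `Nc1c2c(=O)[nH]c(-c3ccccc3)cc2nn1-c1ccccc1` carries a change of the same kind at that carbon: phenyl in place of tert-butyl on an aromatic carbon. The measured step bears on it only loosely, since phenyl is a different sort of group from tert-butyl and nothing measured here contains a phenyl at that place. A modest rise or no change beyond the scatter is therefore expected. The step thus expected is a number 7 percentage points higher from compound 2 to compound 3 (within the scatter). Compound 3 is expected to give about 12%, within a range from -10% to 35%.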

Compound 3, a percentage reported as inhibition, at one concentration (the size of the read-out at that concentration, not a potency): 38%
For compound 3 the middle estimate is 26 percentage points below the measured one, and the stated range ends below it.
By their numbers in this assay, from the lowest: compound 1; then compound 2; then compound 3.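

In this assay the choice of group at this aromatic carbon matters more than the first step suggested: phenyl in place of tert-butyl gives a number 33 percentage points higher from compound 2 to compound 3 (beyond the scatter) and phenyl in place of methyl gives a number 49 percentage points higher from compound 1 to compound 3 (beyond the scatter) for the same core. Both steps are large, whereas the earlier exchange of one ringless carbon group for another gave only a modest rise, and among these three compounds the one with an aromatic ring at this place stands highest. The data offer no explanation for this rise.

As far as these compounds go, whether any ring at this carbon would do the same remains open, as would be tested by a cyclohexyl group, a pyridyl ring or a phenyl ring carrying a methoxy group or a chlorine. A reading at one concentration also leaves the potency of compound 3 open.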